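This account rests on a few compounds, and the source may have more. Where it says the series, first, only, none or still open, it means among the compounds named here.

Three amides share a core in which an amino acid is joined to a benzylamine. Compound 1 `CC(C)[C@@H](N)C(=O)NCc1ccc(Cl)cc1` carries the smaller branched side chain, and in a functional assay on the whole organism (strain albino Sprague-Dawley) with Rattus norvegicus as the target, in the maximal electroshock model (on this read-out lower numbers stand for an effect already at smaller amounts and higher numbers for an effect only at larger amounts of compound), compound 1 gives "not determined" (no result reported). Compound 2 `CC(C)(C)[C@@H](N)C(=O)NCc1ccccc1` and compound 3 `CC(C)(C)[C@@H](N)C(=O)NCc1ccc(OC(F)(F)F)cc1` carry the other side chain and differ only on the aromatic ring. In this assay compound 2 gives 11 mg/kg, and in this assay compound 3 gives 23 mg/kg. Among the compounds with values here, the one recorded step is a 2.1-fold higher number from compound 2 to compound 3 (0.32 log units; beyond the scatter). Compound 3 thus stands at the higher of the two numbers, with compound 2 as its nearest neighbour.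

Compound 4 `CC(C)(C)[C@@H](N)C(=O)NCc1ccc(Cl)cc1` differs from compound 3 by chloro in place of trifluoromethoxy on an aromatic carbon. Within the data shown here, no measured pair sets chloro against trifluoromethoxy, so only that modest step from hydrogen to trifluoromethoxy bears on the question. Chloro is a single heavy atom where trifluoromethoxy has five, so the substitution of compound 4 lies between that of compound 2 and compound 3. For compound 4 the expected step is therefore a 1.5-fold lower number from compound 3 to compound 4 (0.19 log units; within the scatter), a modest drop or none beyond the scatter. Compound 4 is estimated to give 15 mg/kg, within a range from 7 mg/kg to 30 mg/kg.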

Compound 4, dose for half-maximal effect: 30 mg/kg
The estimate for compound 4 lay 2.0-fold (0.30 log units) below the measured number, and the stated range covers the measured number.
By their numbers in this assay, from the lowest: compound 2; then compounds 3 and 4 (each within the scatter of the next).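

With chloro on this aromatic carbon, this assay gives a 2.7-fold higher number from compound 2 to compound 4 (0.44 log units; beyond the scatter), so a second and much smaller group also moves the number away from that of the unsubstituted ring, as trifluoromethoxy did. Chloro in place of trifluoromethoxy gives a 1.3-fold higher number from compound 3 to compound 4 (0.12 log units; within the scatter), which lies within the scatter, so a group of one heavy atom and a group of five cannot be told apart at this place, para to a large group. No measurement here explains why either group raises the number compared with hydrogen.

From the compounds shown here alone, it remains open whether a methyl group or an amine on the same carbon would also raise the number above that of compound 2. Going by these compounds, it is equally open whether any group there could bring the number below that of compound 2.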